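Azaindole in place of aminopyridine on a benzoxazolone core

The source may hold more compounds than are shown below. What is called first, only, known or untested is meant among the compounds shown, and "the series" means these compounds.

Measured so far:
Compound 1, `Nc1ccc(-c2ccc3c(c2)oc(=O)n3Cc2ccc(F)cc2)cn1`: 16500 nM
Compound 2, `O=c1oc2cc(-c3cnc4[nH]ccc4c3)ccc2n1Cc1ccc(F)cc1`: 5990 nM
Compound 3, `Nc1ncnn2c(-c3ccc4c(c3)oc(=O)n4Cc3ccc(F)cc3)ccc12`: > 100000 nM

The three compounds were tested in a functional assay on HCT-116 cells (Homo sapiens) for inhibition, read by MTT assay, with a stated time of 72 h; on this read-out higher numbers stand for weaker inhibition and lower numbers for stronger inhibition. Compound 1 gives 16500 nM, the highest of the two numbers reported, with compound 2 at 5990 nM the nearest to it. For compound 3 the assay gave only a limit, > 100000 nM, so that this compound sits at the limit of > 100000 nM in this assay, at which 1 of the 3 values shown sits, rather than at a number.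

The step from compound 1 to compound 4, `O=c1oc2cc(-c3c[nH]c4ncccc34)ccc2n1Cc1ccc(F)cc1`, replaces (a group of 9 heavy atoms (7 carbon, 2 nitrogen; one five-membered aromatic ring with 1 hetero atom, one six-membered aromatic ring with 1 hetero atom) in place of a group of 7 heavy atoms (5 carbon, 2 nitrogen; one six-membered aromatic ring with 1 hetero atom), on an aromatic carbon).

One measured step speaks to this kind of change: a 2.8-fold lower number from compound 1 to compound 2 (0.44 log units; beyond the scatter), where a bicyclic group of the same size and atom count took the place of the 6-aminopyridin-3-yl group on the same aromatic carbon. The group entering in compound 4 differs from that of compound 2 in where its rings are joined to the core, so the earlier step is a guide only in its direction. A modest fall in the number, of the order seen from compound 1 to compound 2, is therefore expected in this assay, with a wide margin for the changed attachment.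

Compound 4 is estimated at 8000 nM, with a range from 2500 nM to 30000 nM, which would mean a step of a 2.1-fold lower number from compound 1 to compound 4 (0.31 log units; beyond the scatter).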

Compound 4, half-maximal inhibitory concentration: 11800 nM
Estimate against measurement, compound 4: 1.5-fold (0.17 log units) below, within the range that was stated.
By their numbers in this assay, from the lowest: compounds 2, 4 and 1 (each within the scatter of the next, the first and the last beyond it). At a limit, above all of these: compound 3.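

In this assay, moving the point at which the bicyclic group joins the core leaves the two bicyclic compounds unresolved: a 2.0-fold higher number from compound 2 to compound 4 (0.29 log units; within the scatter). The larger group therefore does not in itself set a compound apart from the aminopyridine, since a 1.4-fold lower number from compound 1 to compound 4 (0.15 log units; within the scatter), whereas only compound 2 among these three is separated from compound 1 by more than the scatter, and compound 2 and compound 4 cannot be told apart either. This aromatic carbon is thus shown to tolerate two different attachments of the bicyclic group with little visible consequence, while compound 3, which carries a different group on the same carbon, remains at a limit of the assay: the limit of > 100000 nM in this assay, at which 1 of the 4 values shown sits.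

Going by these compounds, all four compounds share the same core and the same fluorinated benzyl group, so it stays open whether a morpholine or a carboxylic acid in place of that benzyl group would shift these numbers at all. Nothing given here accounts for how close the values of compound 1, compound 2 and compound 4 lie.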